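A tail swap on a shared core, measured in cells

The source may report more compounds than this note shows. Statements on the series, on what has been measured and on what is new or still open speak of the compounds shown alone.

Compound 1 `COc1cc2ncnc(N3CCCc4ccccc43)c2cc1NC(=O)C=C(C)C` gives 6130 nM
Compound 2 `CC/C=C/C(=O)Nc1cc2c(N3CCCc4ccccc43)ncnc2cc1OC` gives 6310 nM
Compound 3 `COc1cc2ncnc(N3CCCc4ccccc43)c2cc1NC(=O)/C=C/CN1CCN(C)CC1` gives 6260 nM

All three numbers come from a functional assay on PC-3 cells (Homo sapiens) for antiproliferative activity, read by MTT assay, with a stated time of 72 h; a higher number here means a weaker inhibitor, a lower number a stronger inhibitor. The three compounds share one core and differ only in the group on the carbonyl carbon of the amide. The step of a 1.0-fold higher number from compound 1 to compound 2 (0.01 log units; within the scatter) and the step of a 1.0-fold higher number from compound 1 to compound 3 (0.01 log units; within the scatter) both lie within the scatter, as does the step of a 1.0-fold lower number from compound 2 to compound 3 (0.00 log units; within the scatter). Compound 3 thus stands second highest of the three, yet its distance to either neighbour is no more than the scatter of the measurement, so nothing separates it from compound 1 or compound 2.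

Compound 4 `COc1cc2ncnc(N3CCCc4ccccc43)c2cc1NC(=O)/C=C/CN1CCC(CO)CC1` is not yet measured. It differs from compound 3 in one place: 4-(hydroxymethyl)piperidin-1-yl in place of 4-methylpiperazin-1-yl on a saturated chain carbon bound to a double-bonded chain carbon. The change again touches only the tail beyond the double bond, the same region in which the earlier replacements were made without a shift beyond the scatter. Because a 1.0-fold lower number from compound 2 to compound 3 (0.00 log units; within the scatter) was flat, a further exchange of the saturated ring at that position is expected to read flat as well, with the estimated step of a 1.0-fold higher number from compound 3 to compound 4 (0.00 log units; within the scatter). Compound 4 is therefore expected to give about 6300 nM in this assay, within a range from 3000 nM to 13000 nM.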

Compound 4, half-maximal inhibitory concentration: 7150 nM
Estimate against measurement, compound 4: 1.1-fold (0.05 log units) below, and the stated range covers the measured number.
By their numbers in this assay, from the lowest: compounds 1, 3, 2 and 4 (each within the scatter of the next).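

In this assay, the change at the saturated chain carbon bound to a double-bonded chain carbon now goes beyond a simple ring exchange: 4-(hydroxymethyl)piperidin-1-yl has one ring hetero atom where 4-methylpiperazin-1-yl has two, and it brings a hydrogen-bond donor where the leaving group has none, yet the step stays within the scatter (a 1.1-fold higher number from compound 3 to compound 4 (0.06 log units; within the scatter)). The same holds when the new group is set against plain methyl at this place (a 1.1-fold higher number from compound 2 to compound 4 (0.05 log units; within the scatter)), and when the whole 3-(4-(hydroxymethyl)piperidin-1-yl)prop-1-en-1-yl tail is set against 2-methylprop-1-en-1-yl on the carbonyl carbon (a 1.2-fold higher number from compound 1 to compound 4 (0.07 log units; within the scatter)). Small alkyl ends and both saturated rings thus read alike here, so none of the four compounds can be placed ahead of another on this read-out.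

On these data alone, whether a carboxylic acid or a primary amine on the tail, or a longer chain carrying the ring, would shift the number beyond the scatter remains open. Nothing given here explains why the numbers stay so close.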